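Chain-shortened tetraacetate: from compound 1 to compound 4

A few compounds are considered here, and "the series" means these few. Any claim that something is new, unique, unknown or untested is made for them only; others in the source may bear on it.

Compound 1 `CCCCCCCCCCCCCCCCCC(=O)Nc1nnc(S[C@@H]2O[C@H](COC(C)=O)[C@H](OC(C)=O)[C@H](OC(C)=O)[C@H]2OC(C)=O)s1` carries a saturated chain on its amide and four acetates on the sugar. In a functional assay on HeLa cells (Homo sapiens) for cytotoxicity, read by MTT assay, with a stated time of 24 h (a higher number here means a weaker inhibitor, a lower number a stronger inhibitor), compound 1 gives 97500 nM, the highest number of the three measured; compound 2 `CCCCCCCCCCCCCCCCCC(=O)Nc1nnc(S[C@@H]2O[C@H](CO)[C@H](O)[C@H](O)[C@H]2O)s1`, with free hydroxyls, gives 11200 nM, and compound 3 `CCCCCCCC/C=C\CCCCCCCC(=O)Nc1nnc(S[C@@H]2O[C@H](CO)[C@H](O)[C@H](O)[C@H]2O)s1`, with the unsaturated chain, gives 8800 nM. Going by the values given here, the only single-place step measured, a 1.3-fold lower number from compound 2 to compound 3 (0.10 log units; within the scatter), concerns unsaturation on the chain and stays within the scatter. Compound 4 `C=CCCCCCCCCC(=O)Nc1nnc(S[C@@H]2O[C@H](COC(C)=O)[C@H](OC(C)=O)[C@H](OC(C)=O)[C@H]2OC(C)=O)s1` differs from compound 1 by vinyl in place of nonyl on a saturated chain carbon, eight bonds along the chain from a carbonyl carbon. Among the compounds with values here, no measured step tells how chain length itself moves this assay, so no step beyond the scatter is expected: the estimate is a 1.1-fold lower number from compound 1 to compound 4 (0.03 log units; within the scatter), giving compound 4 an expected 90000 nM, within 30000 nM to 270000 nM.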

Compound 4, half-maximal inhibitory concentration: 77700 nM
Compound 4: the middle estimate sits 1.2-fold (0.06 log units) above what was measured; the range from low to high includes it.
By their numbers in this assay, from the lowest: compounds 3 and 2 (each within the scatter of the next); then compounds 4 and 1 (each within the scatter of the next).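

In this assay the tetraacetate shows no response to a large change in the chain: a 1.3-fold lower number from compound 1 to compound 4 (0.10 log units; within the scatter), with vinyl in place of nonyl on a saturated chain carbon, eight bonds along the chain from a carbonyl carbon. The earlier step covered only unsaturation among free-hydroxyl compounds, whereas this one removes chain carbons and adds a double bond together. No measured evidence accounts for this result.

The two changes cannot be read apart here. Still open, from the compounds shown here alone, is whether a carboxylic acid or an amine in place of vinyl would stay within the scatter of compound 1, and whether vinyl would do so on the free-hydroxyl compound 2.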